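The source may report more compounds than this note shows. Statements on the series, on what has been measured and on what is new or still open speak of the compounds shown alone.

In an in vivo functional assay on the whole organism for inhibition, with Rattus norvegicus as the target (on this read-out higher numbers stand for an effect only at larger amounts of compound and lower numbers for an effect already at smaller amounts), compound 1 (`CCCCc1nc(C)c(CC(=O)O)c(=O)n1Cc1ccc(-c2ccccc2-c2nnn[nH]2)cc1`) gives 0.13 mg/kg and compound 2 (`CCCCc1nc(C)c(CC(=O)N(C)C)c(=O)n1Cc1ccc(-c2ccccc2-c2nnn[nH]2)cc1`) gives 0.018 mg/kg while compound 3 (`CCCCc1nc(C)c(CC(=O)N(CC)CC)c(=O)n1Cc1ccc(-c2ccccc2-c2nnn[nH]2)cc1`) gives 0.089 mg/kg on the same read-out. Compound 3 therefore lies within the scatter of compound 1 (a 1.5-fold lower number from compound 1 to compound 3 (0.16 log units; within the scatter)) and clearly apart from compound 2. Compound 4 (`CCCCc1nc(C)c(CC(=O)N2CCCC2)c(=O)n1Cc1ccc(-c2ccccc2-c2nnn[nH]2)cc1`) differs from compound 3 by one change (pyrrolidin-1-yl in place of diethylamino on a carbonyl carbon) with pyrrolidin-1-yl in place of diethylamino on a carbonyl carbon. No ring in this place has been measured yet. The closest guide is compound 2 (a 4.9-fold higher number from compound 2 to compound 3 (0.69 log units; beyond the scatter)) and that modest step suggests that a different amino group here can matter, while a 7.2-fold lower number from compound 1 to compound 2 (0.86 log units; beyond the scatter) shows the same. A partial move toward compound 2 seems likely. The expected change is a 2.2-fold lower number from compound 3 to compound 4 (0.35 log units; beyond the scatter) in this assay and may barely clear the scatter. The estimate for compound 4 is 0.04 mg/kg with an expected range from 0.012 mg/kg to 0.13 mg/kg on this scale.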

Compound 4, dose for half-maximal effect: 0.056 mg/kg
Estimate against measurement, compound 4: 1.4-fold (0.15 log units) below; measured number inside the range.
By their numbers in this assay, from the lowest: compound 2; then compounds 4, 3 and 1 (each within the scatter of the next, the first and the last beyond it).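

Closing the two ethyl chains into a pyrrolidin-1-yl ring keeps the heavy-atom count the same and gives (a 1.6-fold lower number from compound 3 to compound 4 (0.20 log units; within the scatter)), so on this read-out the ring cannot be told apart from diethylamino. The ring amide remains clearly apart from the dimethylamino amide (a 3.1-fold higher number from compound 2 to compound 4 (0.49 log units; beyond the scatter)) and from the carboxylic acid (a 2.3-fold lower number from compound 1 to compound 4 (0.37 log units; beyond the scatter)), leaving compound 2 with the lowest number of the four. No measured data explain these steps. Going by these compounds, it remains open whether piperidin-1-yl, morpholin-4-yl or a simple methylamino group on the same carbonyl carbon would come close to compound 2.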